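Swapping the aminopyridine for a hydroxyphenyl group

This account rests on a few compounds, and the source may have more. Where it says the series, first, only, none or still open, it means among the compounds named here.

Values in a functional assay on RD cells (Homo sapiens) for inhibition, read by luminescence and ATP content, with a stated time of 72 h (a higher number here means that more compound is tolerated, a lower number that less compound is tolerated), each one a limit:
- Compound 1 `CCOC(=O)c1cnc2ccc(-c3ccc(C(C)C)cc3)cc2c1`: > 7400 nM
- Compound 2 `Nc1ccc(-c2ccc3ncc(-c4noc(C(F)(F)F)n4)cc3c2)cn1`: > 2500 nM
- Compound 3 `Cc1nc(-c2cnc3ccc(-c4ccc(N)nc4)cc3c2)no1`: > 7400 nM

Compound 3 stands at the limit of > 7400 nM in this assay, at which 2 of the 3 values shown sit, so its place is a limit and not a number. Compound 4 `Cc1nc(-c2cnc3ccc(-c4ccc(O)cc4)cc3c2)no1` differs from it as follows: 4-hydroxyphenyl in place of 6-aminopyridin-3-yl on an aromatic carbon. Here 4-hydroxyphenyl enters in place of 6-aminopyridin-3-yl on an aromatic carbon. Among the measured compounds shown here, the only measured step is a step that the two limits leave unreadable from compound 2 to compound 3. It concerns another place in the structure and offers no size to carry over. The expectation therefore rests on compound 3 alone, whose > 7400 nM is a limit. No step beyond the scatter is expected, and the estimated step is a step that the limit leaves unreadable from compound 3 to compound 4. For compound 4 the estimated value is 9000 nM. The expected range runs from 3000 nM to 25000 nM.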

Compound 4, half-maximal cytotoxic concentration: > 2500 nM
Compound 4: only a limit was reported; the forecaster's own chance of this, stated with the estimate: 65%; the middle value is on the limit's open side.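

Among the compounds shown here, compound 3 and compound 4 are both reported only as limits in this assay, so no step between them can be read. The compounds shown leave open whether 4-hydroxyphenyl in place of 6-aminopyridin-3-yl changes the tolerated concentration at all.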